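The source may hold more compounds than are shown below. What is called first, only, known or untested is meant among the compounds shown, and "the series" means these compounds.

Measured so far in a toxicity assay on HeLa cells (Homo sapiens) for cytotoxicity, read by colorimetric assay, with a stated time of 72 h; on this read-out lower numbers stand for higher toxicity in this test and higher numbers for lower toxicity in this test:
compound 1 `CN1CCC(CCCC2CCN(c3nc(=O)c4cc(C(F)(F)F)cc([N+](=O)[O-])c4s3)CC2)CC1`, where compound 1 gives 20100 nM
compound 2 `O=c1nc(N2CC[C@@H](c3ccc(F)cc3)[C@H](O)C2)sc2c([N+](=O)[O-])cc(C(F)(F)F)cc12`, where compound 2 gives 68400 nM
compound 3 `N#Cc1ccccc1N1CCN(c2nc(=O)c3cc(C(F)(F)F)cc([N+](=O)[O-])c3s2)CC1`, where compound 3 gives only a limit, > 108000 nM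

Compound 3 stands at the edge of what this assay reports; its entry is a limit and not a number, as set out in the limit of > 108000 nM in this assay, at which 1 of the 3 values shown sits. Compounds 1 and 2 carry numbers, both toward the weaker end of cytotoxicity.

Compound 4 `COc1cc(OC)cc(N2CCN(c3nc(=O)c4cc(C(F)(F)F)cc([N+](=O)[O-])c4s3)CC2)c1` differs from compound 3 in one place: 3,5-dimethoxyphenyl in place of 2-cyanophenyl on an amine nitrogen in a ring. No measured step of this kind exists among the three compounds shown. In this assay the change from compound 3 to compound 4 is expected to bring no shift beyond the scatter, an at least 1.1-fold lower number from compound 3 to compound 4 (0.05 log units; that floor lies within the scatter). Compound 4 is estimated at 95000 nM, with a range from 40000 nM to 220000 nM, and a limit rather than a number remains likely.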

Compound 4, half-maximal cytotoxic concentration: > 101000 nM
Compound 4 gave a limit, no number; the forecaster's own chance of this, stated with the estimate: 55%; middle value at least 1.0-fold (0.02 log units) from the limit.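

In this assay compound 3 and compound 4 both stand as limits, not numbers, so the step between them cannot be read. Going by these compounds, whether 2-cyanophenyl or 3,5-dimethoxyphenyl on an amine nitrogen in a ring gives the lower number in this assay stays open.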